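Aryloxy variation on the shared core: cytotoxicity notes

A few compounds are considered here, and "the series" means these few. Any claim that something is new, unique, unknown or untested is made for them only; others in the source may bear on it.

Measured compounds:
compound 1 `Cc1cccc(Oc2nc(Nc3ccc(C#N)cc3)nc3ccccc23)c1` — 355000 nM
compound 2 `COc1ccccc1Oc1nc(Nc2ccc(C#N)cc2)nc2ccccc12` — 150000 nM
compound 3 `N#Cc1ccc(Nc2nc(Oc3ccc(Br)cc3)c3ccccc3n2)cc1` — 215000 nM

In an ADME assay on MT4 cells (Homo sapiens) for cytotoxicity, read by MTT assay, with a stated time of 4 days (on this read-out lower numbers stand for higher toxicity in this test and higher numbers for lower toxicity in this test), compound 3 gives 215000 nM, the second highest of the three numbers; its nearest neighbour is compound 2 and its furthest is compound 1, and both gaps lie within the scatter, so no order among the three can be read from this set.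

Compound 4 `Cc1cc(C)c(Oc2nc(Nc3ccc(C#N)cc3)nc3ccccc23)c(C)c1` is not yet measured. It differs from compound 3 in one place: 2,4,6-trimethylphenyl in place of 4-bromophenyl on an oxygen on an aromatic ring.

Steps that bear on this change are those in which the group on the oxygen on the aromatic ring was exchanged. Within the data shown here, the step of a 1.7-fold lower number from compound 1 to compound 3 (0.22 log units; within the scatter) and the step of a 1.4-fold higher number from compound 2 to compound 3 (0.16 log units; within the scatter) both stay within the scatter; only the step of a 2.4-fold lower number from compound 1 to compound 2 (0.37 log units; beyond the scatter) goes beyond it, and modestly. Three different groups at this position have thus left the read-out of this assay in a narrow band. On that basis the step of a 1.2-fold higher number from compound 3 to compound 4 (0.07 log units; within the scatter) is expected to be small, with no direction beyond the scatter predicted. Compound 4 is therefore estimated at 250000 nM, with a range from 100000 nM to 550000 nM.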

Compound 4, half-maximal cytotoxic concentration: > 34000 nM
Compound 4: no number, only a limit; the forecaster's own chance of this, stated with the estimate: 20%; the middle value lies beyond the limit too.
By their numbers in this assay, from the lowest: compounds 2, 3 and 1 (each within the scatter of the next, the first and the last beyond it).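

In this assay compound 4 gives > 34000 nM, which is a limit and not a number. The steps to compound 4 from compound 1, compound 2 and compound 3 therefore cannot be read: the limit of > 34000 nM in this assay, at which 1 of the 4 values shown sits.

As far as these compounds go, whether 2,4,6-trimethylphenyl on the oxygen keeps the read-out in the same band as the other three groups remains open.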